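Trading an amide tail for hydroxy

The source may hold more compounds than are shown below. What is called first, only, known or untested is meant among the compounds shown, and "the series" means these compounds.

In an ADME assay on L929 cells (Mus musculus) for cytotoxicity, read by resazurin assay, with a stated time of 48 h (on this read-out higher numbers stand for lower toxicity in this test and lower numbers for higher toxicity in this test), compound 3 (`CN(C)C(=O)CCCn1c2ccc([N+](=O)[O-])cc2c(=O)n1Cc1ccccc1`) gives > 256000 nM, which is a limit and not a number. Compound 2 (`N#CCn1c2ccc([N+](=O)[O-])cc2c(=O)n1Cc1ccccc1`) gives > 256000 nM, also a limit. Compound 1 (`COC(=O)Cn1c2ccc([N+](=O)[O-])cc2c(=O)n1Cc1ccccc1`) gives 129000 nM. The series thus shows (the limit of > 256000 nM in this assay, at which 2 of the 3 values shown sit).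

Compound 4 (`O=c1c2cc([N+](=O)[O-])ccc2n(CCO)n1Cc1ccccc1`) carries hydroxy in place of (dimethylcarbamoyl)methyl on a saturated chain carbon, two bonds along the chain from an aromatic nitrogen.

The measured changes on this chain are an at least 1.9-fold higher number from compound 1 to compound 2 (0.29 log units; that floor lies within the scatter) and an at least 1.9-fold higher number from compound 1 to compound 3 (0.29 log units; that floor lies within the scatter), while a step that the two limits leave unreadable from compound 2 to compound 3. None of them shows a step beyond the scatter, so none beyond it is expected in this assay here. The expected step is an at least 1.2-fold lower number from compound 3 to compound 4 (0.10 log units; that floor lies within the scatter). For compound 4 the estimated value is 200000 nM, within a range from 100000 nM to 400000 nM.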

Compound 4, concentration lethal to 50% of the cells: > 256000 nM
Compound 4: no number, only a limit (the forecaster's own chance of this, stated with the estimate: 55%); middle value at least 1.2-fold (0.10 log units) from the limit.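

In this assay, the 3-(dimethylcarbamoyl)propyl chain can give way to the much smaller 2-hydroxyethyl chain, and the result is still a limit and not a number. Measured against the methoxycarbonyl chain, the change to the hydroxy chain gives an at least 1.9-fold higher number from compound 1 to compound 4 (0.29 log units; that floor lies within the scatter). The steps from compound 2 and from compound 3 to compound 4 cannot be read, because both ends of each step are limits: the limit of > 256000 nM in this assay, at which 3 of the 4 values shown sit.

As far as these compounds go, whether an amine or a carboxylic acid at the end of this chain would give a measurable number stays open. So does how the true values of compound 2, compound 3 and compound 4 compare.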